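This account rests on a few compounds, and the source may have more. Where it says the series, first, only, none or still open, it means among the compounds named here.

Measured in an assay on CHO cells for displacement of a labelled ligand from adenosine receptor A3 (Homo sapiens), read by scintillation counting, with a stated time of 45 min, in the presence of a further agent that is not named here; on this read-out lower numbers stand for stronger inhibition and higher numbers for weaker inhibition:
compound 1 `CCCn1c(=O)[nH]c2nc(-c3ccc(S(=O)(=O)N4CCN(Cc5cccc(C)c5)CC4)cc3)[nH]c2c1=O` gives > 1000 nM, a limit.
compound 2 `CCCn1c(=O)[nH]c2nc(-c3ccc(S(=O)(=O)N4CCN(c5ccccc5Br)CC4)cc3)[nH]c2c1=O` gives > 1000 nM, a limit.

Compound 2 stands at the limit of this assay. Both values shown sit at that limit (the limit of > 1000 nM in this assay, at which 2 of the 2 values shown sit). Among the measured compounds shown here, the one measured step, a step that the two limits leave unreadable from compound 1 to compound 2, is therefore unreadable in size. Compound 3 `CCCn1c(=O)[nH]c2nc(-c3ccc(S(=O)(=O)N4CCN(c5cccc(Br)c5)CC4)cc3)[nH]c2c1=O` differs by 3-bromophenyl in place of 2-bromophenyl on an amine nitrogen in a ring. For the measured compounds named here, no measured step bears on this change, so no step beyond the scatter can be foreseen. The expected step that the limit leaves unreadable from compound 2 to compound 3 is near none, with a limit again the most likely outcome. Compound 3 is estimated at 3000 nM, range 1000 nM to 20000 nM.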

Compound 3, inhibition constant: > 1000 nM
Compound 3: a limit, no number (the forecaster's own chance of this, stated with the estimate: 80%); the middle value is on the limit's open side.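

In this assay compound 3 gives > 1000 nM, a limit. Among the compounds shown here, no step among compound 1, compound 2 and compound 3 can be read: the limit of > 1000 nM in this assay, at which 3 of the 3 values shown sit. The compounds shown leave open whether the 3-methylbenzyl, 2-bromophenyl and 3-bromophenyl groups differ at all on this read-out.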